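Moving the chloro on the aryl ring of compound 2

The source may report more compounds than this note shows. Statements on the series, on what has been measured and on what is new or still open speak of the compounds shown alone.

Compound 2 `Cc1c(C(=O)NCc2cccc(C(F)(F)F)c2)cnn1-c1cccc(Cl)c1` sits at the edge of the measured range: in a functional assay on cells for antagonist activity at C-C chemokine receptor type 1 (Homo sapiens), read by FLIPR and calcium flux (a higher number here means a weaker inhibitor, a lower number a stronger inhibitor), compound 2 gives > 3000 nM, which is a limit of the assay rather than a number (the limit of > 3000 nM in this assay, at which 1 of the 2 values shown sits). Compound 1 `Cc1c(C(=O)NCc2cccc(C(F)(F)F)c2)cnn1-c1ccc(Cl)c(Cl)c1` gives 500 nM in this assay. The step of an at least 6.0-fold higher number from compound 1 to compound 2 (0.77 log units; beyond the scatter) shows that hydrogen in place of chloro costs potency. For the measured compounds named here, compound 3 `Cc1c(C(=O)NCc2cccc(C(F)(F)F)c2)cnn1-c1ccccc1Cl` differs from compound 2 by 2-chlorophenyl in place of 3-chlorophenyl on an aromatic nitrogen, a change for which no measured step exists; the single step available concerns loss of a chloro, not its placement. The expected step of a number no higher from compound 2 to compound 3 (the limit leaves the size open) is therefore close to none, with wide uncertainty. Compound 3 is estimated at 3000 nM, range 700 nM to 12000 nM.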

Compound 3, half-maximal inhibitory concentration: > 3000 nM
Compound 3: no number, only a limit; the forecaster's own chance of this, stated with the estimate: 50%; the middle value lies on the limit itself.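

Compound 3 gives > 3000 nM in this assay, a limit of the assay and not a number. Replacing 3,4-dichlorophenyl with 2-chlorophenyl on the aromatic nitrogen gives an at least 6.0-fold higher number from compound 1 to compound 3 (0.77 log units; beyond the scatter), so neither single-chloro placement shown keeps the potency of compound 1. The step between compound 2 and compound 3 cannot be read, and any effect of moving the chloro stays hidden, both compounds sitting at one limit: the limit of > 3000 nM in this assay, at which 2 of the 3 values shown sit.

From the compounds shown here alone, how far either single-chloro compound lies past that limit remains open. Also open, going by these compounds, is whether an amine or a carboxylic acid on this aryl ring would restore any potency.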